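The source may report more compounds than this note shows. Statements on the series, on what has been measured and on what is new or still open speak of the compounds shown alone.

Measured so far in an ADME assay on S9 fraction from liver (Rattus norvegicus, strain Wistar) for metabolic stability, tested at 0.1 uM (on this read-out lower numbers stand for slow clearance and higher numbers for fast clearance), for three compounds:

Compound 1 `CN(C)c1cc(OCc2cc(F)c(Oc3ccc(Cl)c(C(F)(F)F)c3)c(F)c2)nc(=O)n1C` gives 82.8 mL/min/kg
Compound 2 `CCN(CC)c1cc(OCc2cc(F)c(Oc3ccc(Cl)c(C(F)(F)F)c3)c(F)c2)nc(=O)n1C` gives 41.9 mL/min/kg
Compound 3 `Cn1c(N2CCCCC2)cc(OCc2cc(F)c(Oc3ccc(Cl)c(C(F)(F)F)c3)c(F)c2)nc1=O` gives 21.8 mL/min/kg

Compound 3 sits at the low end of these numbers. Its nearest neighbour is separated by a 1.9-fold lower number from compound 2 to compound 3 (0.28 log units; within the scatter) and that gap is no real separation, whereas a 3.8-fold lower number from compound 1 to compound 3 (0.58 log units; beyond the scatter) is a real one.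

Compound 4 `CN1CCN(c2cc(OCc3cc(F)c(Oc4ccc(Cl)c(C(F)(F)F)c4)c(F)c3)nc(=O)n2C)CC1` differs from compound 3 in a single place, with 4-methylpiperazin-1-yl in place of piperidin-1-yl on an aromatic carbon. All three measured steps exchange the group at this same place, so they are the best guide available. Besides the two already given, there is a 2.0-fold lower number from compound 1 to compound 2 (0.30 log units; within the scatter) and it stays within the scatter. Among the measured compounds shown here, none of them introduces a second nitrogen into the ring, so the data hold no direct precedent.

Compound 4 keeps a six-membered ring like compound 3, so no step beyond the scatter is expected in this assay here. The direction is uncertain, with a slight upward lean as a cautious guess for a compound starting from the low end. The expected change is a 1.4-fold higher number from compound 3 to compound 4 (0.14 log units; within the scatter) and it remains a rough estimate. For compound 4 the estimated value is 30 mL/min/kg with an expected range from 12 mL/min/kg to 75 mL/min/kg in this read-out.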

Compound 4, clearance: 1140 mL/min/kg
Beside the measured number, compound 4's estimate is 38-fold (1.58 log units) below it, outside the stated range (above it).
By their numbers in this assay, from the lowest: compounds 3, 2 and 1 (each within the scatter of the next, the first and the last beyond it); then compound 4.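

In this assay, the group on this aromatic carbon, ortho to a methyl group, had seemed forgiving, since dimethylamino, diethylamino and piperidin-1-yl gave numbers no more than modestly apart. Compound 4 shows that this position can respond far more strongly: keeping a six-membered ring but bringing in a second ring nitrogen carrying a methyl group gives a 52-fold higher number from compound 3 to compound 4 (1.72 log units; beyond the scatter) and puts clearance well beyond the earlier range. The open-chain amines tell the same story, with a 27-fold higher number from compound 2 to compound 4 (1.43 log units; beyond the scatter) and a 14-fold higher number from compound 1 to compound 4 (1.14 log units; beyond the scatter), so the size of the ring alone does not set the number, and nothing among the data shown accounts for this jump.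

As far as these compounds go, what remains open is whether the jump belongs to the second ring nitrogen or to the methyl group on it. A piperazin-1-yl group without the methyl, or a morpholin-4-yl group with an oxygen in place of that nitrogen, would help to separate these two parts of the change.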